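The source may report more compounds than this note shows. Statements on the series, on what has been measured and on what is new or still open speak of the compounds shown alone.

Compound 1 `COc1cc(N/C(CCNC2=CC(=O)c3ccccc3C2=O)=N\S(=O)(=O)c2ccc(C)cc2)cc(OC)c1OC`: 7940 nM
Compound 2 `Cc1ccc(S(=O)(=O)/N=C(/CCNC2=CC(=O)c3ccccc3C2=O)Nc2cc(F)c(F)c(F)c2)cc1`: 10200 nM

Going by the values given here, in a functional assay on A549 cells (Homo sapiens) for cytotoxicity, read by MTT assay, with a stated time of 48 h (on this read-out higher numbers stand for weaker inhibition and lower numbers for stronger inhibition), compound 2 gives 10200 nM, the highest of the two numbers so far, though its step from compound 1, a 1.3-fold higher number from compound 1 to compound 2 (0.11 log units; within the scatter), lies within the scatter. Compound 3 `Cc1ccc(S(=O)(=O)/N=C(/CCNC2=CC(=O)c3ccccc3C2=O)NC2CCCCC2)cc1` differs from compound 2 by cyclohexyl in place of 3,4,5-trifluorophenyl on an amine nitrogen. Among the compounds with values here, no measured step involves a cyclohexyl group, so the one step at this position, a 1.3-fold higher number from compound 1 to compound 2 (0.11 log units; within the scatter), gives only weak guidance. With no better information, compound 3 is expected to give 12000 nM, within 4000 nM to 40000 nM, a step of a 1.2-fold higher number from compound 2 to compound 3 (0.07 log units; within the scatter) that is estimated to stay within the scatter.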

Compound 3, half-maximal inhibitory concentration: 14700 nM
For compound 3 the middle estimate is 1.2-fold (0.09 log units) below the measured one, and the stated range covers the measured number.
By their numbers in this assay, from the lowest: compounds 1, 2 and 3 (each within the scatter of the next).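

In this assay the change to cyclohexyl on this amine nitrogen gives a 1.4-fold higher number from compound 2 to compound 3 (0.16 log units; within the scatter) and also a 1.9-fold higher number from compound 1 to compound 3 (0.27 log units; within the scatter) so neither aromatic group is needed to keep the number within the scatter of the others. At this position, a non-aromatic ring of carbon only thus reads like both substituted phenyl rings. No evidence bearing on this result is available.

Going by these compounds, what stays open is whether another group here, such as a carboxylic acid or a longer chain ending in an amine, would move the number beyond the scatter.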